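One Fluorine Moved: What to Expect of Compound 3

The compounds below may be only part of what the source reports. "The series", "measured", "known", "first", "only" and "open" are said of these compounds alone.

Compound 1, `CCCCCCc1cn(C(c2ccccc2)c2cc3cc(Br)ccc3nc2OC)nn1`: 6.08%
Compound 2, `COc1nc2ccc(Br)cc2cc1C(c1ccccc1)n1cc(-c2cccc(F)c2)nn1`: 15.5%

Of the compounds shown here, two have been measured in an ADME assay on PANC-1 cells (Homo sapiens) for cytotoxicity, read by sulforhodamine B assay, with a stated time of 48 h, tested at 10 uM; a higher number here means more inhibition at the concentration tested (going by the name of the read-out), a lower number less inhibition. Compound 1 gives 6.08%, and compound 2 gives 15.5%. Within the data shown here, the only step between them, a number 9.4 percentage points higher from compound 1 to compound 2 (within the scatter), replaces hexyl with 3-fluorophenyl on an aromatic carbon, so the two compounds stand within the scatter of each other and neither can be set above the other.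

Compound 3, `COc1nc2ccc(Br)cc2cc1C(c1ccccc1)n1cc(-c2ccc(F)cc2)nn1`, differs from compound 2 in one place: 4-fluorophenyl in place of 3-fluorophenyl on an aromatic carbon. Among the measured compounds shown here, no measured step moves a fluorine from one position of the phenyl ring to another, so nothing here speaks directly to this change. For the measured compounds named here, the one step that is known, from hexyl to 3-fluorophenyl, stayed within the scatter, and a shift of the fluorine within the same ring is a smaller change than that. Compound 3 is therefore expected to give a step of a number 1.5 percentage points lower from compound 2 to compound 3 (within the scatter), that is, no step beyond the scatter. Compound 3 is estimated at 14%, with a range from 2% to 30%.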

Compound 3, a percentage reported as inhibition, at one concentration (the size of the read-out at that concentration, not a potency): 14.9%
Beside the measured number, compound 3's estimate is 0.9 percentage points below it; the range from low to high includes it.
By their numbers in this assay, from the lowest: compounds 1, 3 and 2 (each within the scatter of the next).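

In this assay, among these compounds, the shift of the fluorine gives a number 0.6 percentage points lower from compound 2 to compound 3 (within the scatter) and this is the first direct reading of a change within the ring: on this aromatic carbon of the five-membered ring, 4-fluorophenyl and 3-fluorophenyl cannot be told apart. Set against the chain, the new compound gives a number 8.8 percentage points higher from compound 1 to compound 3 (within the scatter) and thus repeats what compound 2 showed, with neither fluorophenyl group separated from hexyl in this assay, now for two placements of the fluorine rather than one. No outside evidence bears on these results, and nothing here accounts for how close the three compounds lie.

What an amine, a carboxylic acid or a much shorter chain would give on this aromatic carbon remains open, as all three groups shown are either a fluorophenyl or hexyl. Also open, going by these compounds, is what a change elsewhere on the shared core would do, and whether any group at all at this position can carry a compound beyond the scatter of the others in this assay at the single concentration tested.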